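Where one more fluoro might leave stability

The source may hold more compounds than are shown below. What is called first, only, known or untested is meant among the compounds shown, and "the series" means these compounds.

In an ADME assay on microsomes from liver (Mus musculus) for metabolic stability, read by LC-MS, with a stated time of 1 h, tested at 5 uM (on this read-out lower numbers stand for a less stable compound and higher numbers for a more stable compound), compound 1 `Cc1nc(-c2ccccc2F)c(C(=O)N2CCN(c3cc(Cl)cc(Cl)c3)CC2)o1` gives 49%, compound 2 `Cc1nc(-c2ccc(F)cc2)c(C(=O)N2CCN(c3cc(Cl)cc(Cl)c3)CC2)o1` gives 31.1% and compound 3 `Cc1nc(-c2ccccc2)c(C(=O)N2CCN(c3cc(Cl)cc(Cl)c3)CC2)o1` gives 43.4%. The measurements place these compounds as follows: a number 5.6 percentage points lower from compound 1 to compound 3 (within the scatter), and a number 12.3 percentage points higher from compound 2 to compound 3 (beyond the scatter).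

Compound 4 `Cc1nc(-c2cccc(F)c2)c(C(=O)N2CCN(c3cc(Cl)cc(Cl)c3)CC2)o1` differs from compound 3 by one change, fluoro in place of hydrogen on an aromatic carbon, meta to a large group.

The two steps above bear on this change, since each swaps a fluoro for hydrogen, yet they point in opposite directions. There is also a number 17.9 percentage points lower from compound 1 to compound 2 (beyond the scatter), so the place of the fluoro matters here. In this assay, only a small drop, within the scatter, is therefore expected. The estimated step is a number 4.4 percentage points lower from compound 3 to compound 4 (within the scatter). Compound 4 is expected at 39%, with a range of 27% to 51%.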

Compound 4, percent of the compound remaining: 40.7%
Estimate against measurement, compound 4: 1.7 percentage points below; low and high end bracket the measured number.
By their numbers in this assay, from the lowest: compounds 2, 4, 3 and 1 (each within the scatter of the next, the first and the last beyond it).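

In this assay, 3-fluorophenyl in place of phenyl gives a step within the scatter, a number 2.7 percentage points lower from compound 3 to compound 4 (within the scatter). Compound 4 also lies within the scatter of both other fluoro compounds, a number 9.6 percentage points higher from compound 2 to compound 4 (within the scatter) and a number 8.3 percentage points lower from compound 1 to compound 4 (within the scatter), although those two lie beyond the scatter of each other. Fluoro at this position therefore leaves the number close to that of phenyl, whereas 4-fluorophenyl in compound 2 does not.

Nothing here explains why the place of the fluoro matters. Going by these compounds, whether a larger group at this position, such as methoxy or nitrile, would also stay within the scatter remains open.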